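A few compounds are considered here, and "the series" means these few. Any claim that something is new, unique, unknown or untested is made for them only; others in the source may bear on it.

Compound 1 `O=c1oc(Nc2ccccc2I)nc2ccccc12` is the reference point of this small set. Among the measured compounds shown here, in an assay on isolated protein for inhibition of complement C1r subcomponent (Homo sapiens), with a stated time of 60 min (a higher number here means a weaker inhibitor, a lower number a stronger inhibitor), compound 1 gives 14700 nM, the lowest of the three numbers measured so far. Compound 2 `CN(c1nc2ccccc2c(=O)o1)c1ccccc1I` gives 16600 nM in this assay, and the step of a 1.1-fold higher number from compound 1 to compound 2 (0.05 log units; within the scatter) lies within the scatter, so the two are not distinguished by this measurement. Compound 3 `Cc1ccccc1Nc1nc2ccccc2c(=O)o1` gives 38000 nM, and the step of a 2.6-fold higher number from compound 1 to compound 3 (0.41 log units; beyond the scatter) is a modest loss that does go beyond the scatter.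

Compound 4 `O=c1oc(Nc2ccccc2I)nc2cccc(Cl)c12` is the next compound to be measured. It differs from compound 1 by chloro in place of hydrogen on an aromatic carbon. For the measured compounds named here, neither measured step speaks directly to this change: the step from compound 1 to compound 2 alters a nitrogen, and the step from compound 1 to compound 3 exchanges iodo for methyl, whereas the chloro of compound 4 enters on the fused two-ring part of the shared core, which no measured compound varies. What the two steps do show is that single changes in this series have so far moved the number by a small or modest amount, never a large one. On that basis the step from compound 1 to compound 4 is expected to be small, a 1.2-fold lower number from compound 1 to compound 4 (0.09 log units; within the scatter), in either direction or none beyond the scatter. Compound 4 is therefore estimated at 12000 nM in this assay, with a range from 4500 nM to 32000 nM.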

Compound 4, half-maximal inhibitory concentration: > 62500 nM
Compound 4: only a limit was reported; the forecaster's own chance of this, stated with the estimate: 5%; at least 5.2-fold (0.71 log units) between middle value and limit.
By their numbers in this assay, from the lowest: compounds 1 and 2 (each within the scatter of the next); then compound 3. At a limit, above all of these: compound 4.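

In this assay, compound 4 gives only a limit, > 62500 nM, and not a number. Among the compounds shown here, the result still reads as an at least 4.2-fold higher number from compound 1 to compound 4 (0.62 log units; beyond the scatter), which shows that chloro in place of hydrogen on an aromatic carbon, ortho to a fused ring and meta to a fused ring, is not a neutral change: the fused two-ring part of the shared core, which the earlier compounds left unvaried, does affect the number in this assay. Compound 4 is also the only one of the compounds shown that ends at a limit, so the full size of this loss cannot be read, and the measurement marks only where the reading stops: the limit of > 62500 nM in this assay, at which 1 of the 4 values shown sits.

The compounds shown leave open whether the loss belongs to chloro itself or would also follow from another group at this position, such as fluoro, methoxy or an amine. They also leave open whether chloro on the other aromatic carbons of the shared core would give the same result, and whether chloro here would have the same outcome with methyl in place of iodo, as in compound 3.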